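The source may hold more compounds than are shown below. What is called first, only, known or untested is meant among the compounds shown, and "the series" means these compounds.

Measured in a physicochemical assay for solubility; on this read-out lower numbers stand for lower solubility and higher numbers for higher solubility:
Compound 1 `CNC(=O)c1cc(C(=O)N[C@H]2CC[C@H](O)CC2)n([C@@H](C)c2ccccc2)n1`: >= 180 ug/mL (a limit)
Compound 2 `CCNC(=O)c1cc(C(=O)NC)nn1[C@@H](C)c1ccccc1`: >= 137 ug/mL (a limit)

Compound 2 stands at >= 137 ug/mL, which is a limit and not a number. Its true position on the scale is therefore unknown, and no gap from it can be measured.

Compound 3 `CNC(=O)c1cc(C(=O)N[C@H]2[C@@H]3C[C@@H](O)C[C@@H]32)n([C@@H](C)c2ccccc2)n1` is the next structure to consider. It differs from compound 2 on an amide-type nitrogen: a group of 7 heavy atoms (6 carbon, 1 oxygen; one three-membered non-aromatic ring of carbon only, one five-membered non-aromatic ring of carbon only) in place of a group of 2 heavy atoms (2 carbon; no ring), on an amide-type nitrogen. The entering group therefore replaces ethyl with a larger group carrying a three-membered and a five-membered non-aromatic ring of carbon only.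

Among the measured compounds shown here, the one measured step that bears on this change is a step that the two limits leave unreadable from compound 1 to compound 2, with ethyl in place of 4-hydroxycyclohexyl on an amide-type nitrogen. It gives no size to carry over, and it gives no direction either. The expectation rests instead on compound 1, which also has a larger ring group on that nitrogen and whose limit is >= 180 ug/mL.

No change beyond the usual scatter is expected, and the estimated step is a step that the limit leaves unreadable from compound 2 to compound 3. A further limit is the likeliest report. For compound 3 the expected value is 170 ug/mL, with an estimated range of 100 ug/mL to 220 ug/mL.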

Compound 3, solubility: >= 291 ug/mL
Compound 3: only a limit was reported; the forecaster's own chance of this, stated with the estimate: 75%; middle value at least 1.7-fold (0.23 log units) away from the limit.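

In this assay compound 3 gives >= 291 ug/mL, which is a limit. Among the compounds shown here, compound 1 and compound 2 were also reported only as limits, so no step from either of them to compound 3 can be read. The compounds shown leave open where each true value lies, and whether the group on the amide-type nitrogen alters the read-out at all.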